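This account rests on a few compounds, and the source may have more. Where it says the series, first, only, none or still open, it means among the compounds named here.

Series notes. Compound 1 `CCCCCCCC(=O)Nc1nnc(S[C@@H]2O[C@H](CO)[C@H](O)[C@H](O)[C@H]2O)s1` carries the free sugar on the shared core and in a functional assay on MDA-MB-231 cells (Homo sapiens) for cytotoxicity, read by MTT assay, with a stated time of 24 h (a lower number here means a stronger inhibitor, a higher number a weaker inhibitor), gives 30800 nM. Compound 2 `CCCCCCCC(=O)Nc1nnc(S[C@@H]2O[C@H](COC(C)=O)[C@H](OC(C)=O)[C@H](OC(C)=O)[C@H]2OC(C)=O)s1` is the fully acetylated counterpart of compound 1; in this assay compound 2 gives 18900 nM. Going by the values given here, compound 1 thus has the highest of the two numbers measured so far, but its gap to compound 2 lies within the scatter of repeated measurements, so the two read as equivalent for present purposes. Compound 3 `CCCCCCCC/C=C\CCCCCCCC(=O)Nc1nnc(S[C@@H]2O[C@H](CO)[C@H](O)[C@H](O)[C@H]2O)s1` is the next member to be measured; it differs from compound 1 only in the amide chain: dec-1-en-1-yl in place of hydrogen on a saturated chain carbon, seven bonds along the chain from a carbonyl carbon. Among the compounds with values here, no step between measured compounds bears on this kind of change, so the expectation rests on compound 1 alone. The step of a 2.1-fold lower number from compound 1 to compound 3 (0.31 log units; beyond the scatter) is expected to be modest, toward a lower number, and may not exceed the scatter. Compound 3 is accordingly estimated at 15000 nM, with a plausible range from 5000 nM to 50000 nM.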

Compound 3, half-maximal inhibitory concentration: 43600 nM
Compound 3: middle estimate off by 2.9-fold (0.46 log units), on the low side; the measured number falls inside the stated range.
By their numbers in this assay, from the lowest: compounds 2, 1 and 3 (each within the scatter of the next, the first and the last beyond it).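

In this assay, dec-1-en-1-yl in place of hydrogen on a saturated chain carbon, seven bonds along the chain from a carbonyl carbon, gives a 1.4-fold higher number from compound 1 to compound 3 (0.15 log units; within the scatter) and leaves compound 1 and compound 3 equivalent for present purposes. On this single pair, the amide chain accepts this large addition, double bond included, with no step beyond the scatter, so chain extension at this place has not yet separated the free-sugar compounds. No measurement at hand offers an explanation for this result.

The double bond cannot be read apart from the added length, so a fully saturated chain of the same length remains the direct comparison. Also open, on these data alone, are a shorter chain, an amine or a carboxylic acid at this place, and dec-1-en-1-yl combined with the acetylated sugar of compound 2.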